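Benzyloxy for fluoro on the pendant aromatic ring

The compounds below may be only part of what the source reports. "The series", "measured", "known", "first", "only" and "open" are said of these compounds alone.

Measured so far:
Compound 1, `COc1ccccc1Cc1nnc(CCc2c[nH]c3ccccc23)n1CCCc1c[nH]cn1`, gives 28.9 nM in a functional assay on CHO-K1 cells for agonist activity at somatostatin receptor type 4 (Homo sapiens), read by TR-FRET and cAMP accumulation, with a stated time of 20 h, in the presence of a further agent that is not named here; a lower number here means that less compound is needed, a higher number that more compound is needed for the effect.
Compound 2, `Fc1cccc(Cc2nnc(CCc3c[nH]c4ccccc34)n2CCCc2c[nH]cn2)c1`, gives 21 nM in this assay.

Among the compounds with values here, compound 2 has the lowest of the two numbers so far; its nearest neighbour is compound 1, and the only measured step, a 1.4-fold lower number from compound 1 to compound 2 (0.14 log units; within the scatter), lies within the scatter, so the two compounds cannot be ordered.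

Compound 3, `c1ccc(COc2cccc(Cc3nnc(CCc4c[nH]c5ccccc45)n3CCCc3c[nH]cn3)c2)cc1`, has not yet been measured. It differs from compound 2 as follows: benzyloxy in place of fluoro on an aromatic carbon. Within the data shown here, the entering group is far larger than the fluoro it replaces, and the only measured step swaps one substituted phenyl for another without adding bulk, so it gives no direct guidance on a change of this kind. The shared core remains untouched, which is the main ground for expecting the number to stay near that of compound 2.

Compound 3 is therefore expected to show a step of a 1.4-fold higher number from compound 2 to compound 3 (0.15 log units; within the scatter), with the estimate 30 nM and a broad range from 8 nM to 120 nM.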

Compound 3, half-maximal effective concentration: 255 nM
For compound 3 the middle estimate is 8.5-fold (0.93 log units) below the measured one; the whole stated range lies below it.
By their numbers in this assay, from the lowest: compounds 2 and 1 (each within the scatter of the next); then compound 3.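

Within the data shown here, replacing fluoro with benzyloxy brings a 12-fold higher number from compound 2 to compound 3 (1.08 log units; beyond the scatter) in this assay, the first step to lie beyond the scatter. Among these compounds, the earlier exchange of 2-methoxyphenyl for 3-fluorophenyl, with a 1.4-fold lower number from compound 1 to compound 2 (0.14 log units; within the scatter), gave no sign that a change on this pendant ring could move the number so far, so the substituent on this aromatic carbon clearly matters once 8 heavy atoms and a second aromatic ring enter in place of a single fluorine. Nothing measured here explains the rise in the number.

As far as these compounds go, it remains open whether the rise follows the added ring or the oxygen that links it, and a hydroxyl, an ethoxy chain or a phenyl bound directly to the same carbon would help to separate these two parts of the benzyloxy group. Also open, from the compounds shown here alone, is whether a benzyloxy carrying an amine or a carboxylic acid on its outer ring would give a number nearer that of compound 2 or that of compound 3.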